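Phenyl to Pyridin-2-yl on a Shared Biaryl Amide Core

The compounds below may be only part of what the source reports. "The series", "measured", "known", "first", "only" and "open" are said of these compounds alone.

The measured compounds so far:
- compound 1, `CN1C(=O)C2=C(C1=O)N(CC(=O)Nc1ccc(-c3ccccc3)cc1)CCC2`, gives 12 nM in an assay on cells for inhibition of Protein-serine O-palmitoleoyltransferase porcupine (Homo sapiens), read by reporter gene assay; on this read-out higher numbers stand for weaker inhibition and lower numbers for stronger inhibition
- compound 2, `CN1C(=O)C2=C(C1=O)N(CC(=O)Nc1ccc(-c3cccnc3)nc1)CCC2`, gives 11 nM in this assay
- compound 3, `Cc1ccc(-c2ccc(NC(=O)CN3CCCC4=C3C(=O)N(C)C4=O)nn2)cn1`, gives 29 nM in this assay

Compound 1 stands with the second highest of the three numbers. Its nearest neighbour is compound 2, whose number sits within the scatter of repeated measurements, so no order can be read between the two. Compound 3 lies furthest away: its number is higher than that of compound 1, and the gap goes beyond the scatter.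

Compound 4, `CN1C(=O)C2=C(C1=O)N(CC(=O)Nc1ccc(-c3ccccn3)cc1)CCC2`, has not yet been measured. It differs from compound 1 in one place: pyridin-2-yl in place of phenyl on an aromatic carbon. In words, pyridin-2-yl takes the place of phenyl on an aromatic carbon.

Going by the values given here, no step between measured compounds of this kind has been recorded, so the expectation rests on what compound 1 and compound 2 show. Both carry the same core and return numbers close to each other even though their outer rings differ. From this, a step from compound 1 to compound 4 of no more than the scatter is expected, in either direction, as a 1.3-fold higher number from compound 1 to compound 4 (0.10 log units; within the scatter) expresses. Compound 4 is therefore estimated at 15 nM in this assay, with a range from 6 nM to 40 nM.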

Compound 4, half-maximal inhibitory concentration: 67 nM
Compound 4: middle estimate off by 4.5-fold (0.65 log units), on the low side, outside the stated range (above it).
By their numbers in this assay, from the lowest: compounds 2 and 1 (each within the scatter of the next); then compound 3; then compound 4.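

Pyridin-2-yl in place of phenyl, on the aromatic carbon para to a large group, gives a 5.6-fold higher number from compound 1 to compound 4 (0.75 log units; beyond the scatter) in this assay, and this is the only change in a single place among the compounds shown. The entering and leaving rings have the same number of heavy atoms and differ only in one ring nitrogen and one hydrogen-bond acceptor, so this position proves sensitive to a change that leaves ring size untouched, something the close numbers of compound 1 and compound 2 could not reveal, as those two differ in more than one place. Nothing available here accounts for the loss, so the reason for the step remains unknown.

The compounds shown leave open whether a pyridin-4-yl or pyrimidin-2-yl ring in this same place would track compound 4 or stay with compound 1, and whether a fluoro or methoxy group on the phenyl ring would shift the number at all. They also leave open whether pyridin-2-yl gives a step of similar size when the central ring of the biaryl carries a ring nitrogen.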